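Acetyl to propanoyl in a bis-ether dicarboxylate-type series

A few compounds are considered here, and "the series" means these few. Any claim that something is new, unique, unknown or untested is made for them only; others in the source may bear on it.

Measured compounds:
Compound 1 `Cc1c(OCCCCOc2cccc(C(=O)O)c2)ccc(C(=O)CC(C)C)c1O` gives 84.5% in an assay on HEK293 cells for positive allosteric modulation of metabotropic glutamate receptor 2 (Rattus norvegicus), read by thallium flux, with a stated time of 2.5 min; a higher number here means a larger maximal response, a lower number a smaller maximal response.
Compound 2 `CC(=O)c1ccc(OCCCCOc2ccc(C(=O)O)cc2C)c(C)c1O` gives 83.1%.
Compound 3 `COc1cc(C(=O)O)ccc1OCCCCOc1ccc(C(C)=O)c(O)c1C` gives 86.3%.

On the numbers shown, compound 2 stands together with compound 1 and compound 3; its gaps to both lie within the scatter. Among the compounds with values here, the one single-point step known, a number 3.2 percentage points higher from compound 2 to compound 3 (within the scatter), is itself within the scatter. Compound 4 `CCC(=O)c1ccc(OCCCCOc2ccc(C(=O)O)cc2C)c(C)c1O` differs from compound 2 by methyl in place of hydrogen on a saturated chain carbon bound to a carbonyl carbon. Within the data shown here, no measured step touches this chain position, and compound 1, which carries a longer ketone chain, differs from compound 2 in more than one place, so only its two values can be set side by side. With nothing bearing on the change, no step beyond the scatter is expected: a number 0.9 percentage points higher from compound 2 to compound 4 (within the scatter). Compound 4 is estimated at 84%, with a range from 74% to 94%.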

Compound 4, largest response reached (reported as percent of maximum), in percent of the reference or control that the assay uses: 86.6%
Compound 4: middle estimate off by 2.6 percentage points, on the low side; low and high end bracket the measured number.
By their numbers in this assay, from the lowest: compounds 2, 1, 3 and 4 (each within the scatter of the next).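

In this assay, within the data shown here, acetyl to propanoyl reads a number 3.5 percentage points higher from compound 2 to compound 4 (within the scatter) and so gives the first direct reading at this chain position. One added methyl on the saturated chain carbon bound to the carbonyl carbon leaves the maximal response within the scatter of compound 2. Nothing measured speaks to a cause for this step.

Open, from the compounds shown here alone, is whether a butanoyl chain, a cyclopropyl ketone or an amine on this chain would also stay within the scatter. The longer ketone chain of compound 1 differs from compound 2 in more than one place and does not settle this.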